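Replacing the 4-ethylpiperazin-1-yl Tail and Liver Cell Toxicity

A few compounds are considered here, and "the series" means these few. Any claim that something is new, unique, unknown or untested is made for them only; others in the source may bear on it.

Three compounds sharing one core were tested in an ADME assay on L02 cells (Homo sapiens) for cytotoxicity, read by MTT assay, with a stated time of 48 h; on this read-out higher numbers stand for weaker inhibition and lower numbers for stronger inhibition:

Compound 1 `CCN1CCN(C[C@H]2CN(c3ccc(-n4cc(-c5ccccn5)cn4)c(F)c3)C(=O)O2)CC1` gives 99 ug/mL.
Compound 2 `O=C1O[C@@H](CN2CCCCC2)CN1c1ccc(-n2cc(-c3ccccn3)cn2)c(F)c1` gives > 400 ug/mL, which is a limit of the assay rather than a number.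
Compound 3 `O=C1O[C@@H](CSc2cccs2)CN1c1ccc(-n2cc(-c3ccccn3)cn2)c(F)c1` gives > 400 ug/mL, again a limit of the assay.

Going by the values given here, compound 1 therefore stands alone as the only compound with an actual number; the other two sit at the limit of > 400 ug/mL in this assay, at which 2 of the 3 values shown sit. Both measured steps move away from compound 1 by exchanging the 4-ethylpiperazin-1-yl group: an at least 4.0-fold higher number from compound 1 to compound 2 (0.60 log units; beyond the scatter) and an at least 4.0-fold higher number from compound 1 to compound 3 (0.60 log units; beyond the scatter). The step between compound 2 and compound 3 cannot be read, as both values are limits.

Compound 4 `CCNC(=O)NC[C@H]1CN(c2ccc(-n3cc(-c4ccccn4)cn3)c(F)c2)C(=O)O1` carries the change ((ethylcarbamoyl)amino in place of 4-ethylpiperazin-1-yl on a saturated chain carbon bound to a saturated ring carbon). Both measured steps bear on this change, since each also removed the 4-ethylpiperazin-1-yl group from the same place and each gave at least a modest rise in the number. A rise of similar size is therefore expected in this assay for compound 4, with a fair chance that only a limit is reported. Compound 4 is estimated at 300 ug/mL, in the range 120 ug/mL to 450 ug/mL. The expected step is a 3.0-fold higher number from compound 1 to compound 4 (0.48 log units; beyond the scatter).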

Compound 4, half-maximal inhibitory concentration: > 400 ug/mL
Compound 4: a limit, no number; the forecaster's own chance of this, stated with the estimate: 55%; at least 1.3-fold (0.12 log units) between middle value and limit.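

In this assay, the third replacement for the 4-ethylpiperazin-1-yl group gives an at least 4.0-fold higher number from compound 1 to compound 4 (0.60 log units; beyond the scatter). The earlier replacements, piperidin-1-yl and (thiophen-2-yl)sulfanyl, both carry a ring, whereas (ethylcarbamoyl)amino has none and brings in hydrogen-bond donors that the departing group lacks, so among these compounds a ring in the new group is not needed for the rise on this saturated chain carbon. Compound 4 gives a limit and not a number, so the steps among compounds 2, 3 and 4 cannot be read and these replacements cannot be ranked against each other, leaving compound 1 as the only compound with an actual number: the limit of > 400 ug/mL in this assay, at which 3 of the 4 values shown sit.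

The compounds shown do not tell whether the lower number of compound 1 depends on the whole 4-ethylpiperazin-1-yl group or only on part of it, and a morpholin-4-yl group or a 4-methylpiperazin-1-yl group at this place would help to separate those possibilities. Going by these compounds, how far the number rises for compounds 2, 3 and 4 also stays open, as only limits are available for them.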